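Compound 1 to compound 4: removing the side chain

A few compounds are considered here, and "the series" means these few. Any claim that something is new, unique, unknown or untested is made for them only; others in the source may bear on it.

Compound 1 `CN1CCN(CCC(=O)NC2CC3(N(C)C)CC(c4ccccc4)C2C(c2ccccc2)C3)CC1`: 95000 nM
Compound 2 `CN1CCN(CCC(=O)NC2CC3(N4CCCCC4)CC(c4ccccc4)C2C(c2ccccc2)C3)CC1`: 61100 nM
Compound 3 `CN1CCN(CCC(=O)NC2CC3(N4CCCC4)CC(c4ccccc4)C2C(c2ccccc2)C3)CC1`: 86700 nM

In an ADME assay on L6 cells (Rattus norvegicus) for cytotoxicity, read by resazurin assay, with a stated time of 72 h (a higher number here means a weaker inhibitor, a lower number a stronger inhibitor), compound 1 gives 95000 nM, which lies within the scatter of both other values: a 1.6-fold lower number from compound 1 to compound 2 (0.19 log units; within the scatter) and a 1.1-fold lower number from compound 1 to compound 3 (0.04 log units; within the scatter). Compound 4 `CN(C)C12CC(N)C(C(c3ccccc3)C1)C(c1ccccc1)C2`, not yet measured, carries hydrogen in place of (2-(4-methylpiperazin-1-yl)ethyl)carbonyl on an amine nitrogen. The two measured steps only exchange dimethylamino for piperidin-1-yl or pyrrolidin-1-yl, so neither tests this loss, and the size of the step remains uncertain. A moderate move towards a lower number is expected, namely a 2.1-fold lower number from compound 1 to compound 4 (0.32 log units; beyond the scatter). Compound 4 is estimated at 45000 nM, with an expected range of 12000 nM to 150000 nM.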

Compound 4, half-maximal inhibitory concentration: 40900 nM
Compound 4: the middle estimate sits 1.1-fold (0.04 log units) above what was measured; low and high end bracket the measured number.
By their numbers in this assay, from the lowest: compounds 4, 2, 3 and 1 (each within the scatter of the next, the first and the last beyond it).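

In this assay, losing the (2-(4-methylpiperazin-1-yl)ethyl)carbonyl group from the amine nitrogen gives a 2.3-fold lower number from compound 1 to compound 4 (0.37 log units; beyond the scatter). Among these compounds, this modest step is the first to pass beyond the scatter, whereas the exchanges of the amine on the saturated ring carbon all stayed within it. No available evidence bears on the reason for this step.

On these data alone, it remains open whether the whole side chain or only part of it accounts for the difference. An acetyl group on this nitrogen, or a morpholine ring in place of the 4-methylpiperazine, would separate these parts.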